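Swapping Nitro for Fluoro on Compound 2

The compounds below may be only part of what the source reports. "The series", "measured", "known", "first", "only" and "open" are said of these compounds alone.

Compound 1 `COc1ccc(S(=O)(=O)N2CCc3cccc(NC(=O)c4cccs4)c32)cc1` gives 49 nM
Compound 2 `COc1ccc(S(=O)(=O)N2CCc3cccc(NC(=O)c4ccc([N+](=O)[O-])cc4)c32)cc1` gives 122 nM

Of the two compounds measured in a functional assay on NCI-H460 cells (Homo sapiens) for cytotoxicity (on this read-out higher numbers stand for weaker inhibition and lower numbers for stronger inhibition), compound 2 stands highest at 122 nM and is therefore the weaker inhibitor. Compound 3 `COc1ccc(S(=O)(=O)N2CCc3cccc(NC(=O)c4ccc(F)cc4)c32)cc1` differs from it in one place: fluoro in place of nitro on an aromatic carbon, with fluoro in place of nitro on an aromatic carbon, para to a large group. For the measured compounds named here, only one measured step bears on this change, and only loosely: a 2.5-fold higher number from compound 1 to compound 2 (0.40 log units; beyond the scatter). That modest step replaced a whole group on a carbonyl carbon, putting 4-nitrophenyl in place of thiophen-2-yl. Going by the values given here, no measured step exchanges nitro or fluoro alone, so a small move toward a lower number is all that can be expected in this assay. The expected change is a 1.5-fold lower number from compound 2 to compound 3 (0.18 log units; within the scatter), which is only a rough guess. For compound 3 the estimated value is 80 nM, with an expected range from 30 nM to 220 nM.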

Compound 3, half-maximal inhibitory concentration: 95 nM
The estimate for compound 3 lay 1.2-fold (0.07 log units) below the measured number; measured number inside the range.
By their numbers in this assay, from the lowest: compounds 1, 3 and 2 (each within the scatter of the next, the first and the last beyond it).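

In this assay, fluoro in place of nitro on the six-membered aromatic ring, para to a large group, gives a 1.3-fold lower number from compound 2 to compound 3 (0.11 log units; within the scatter), so this exchange of 3 heavy atoms for 1 leaves the two numbers within the usual scatter of each other. Going the other way in the series, 4-fluorophenyl in place of thiophen-2-yl gives a 1.9-fold higher number from compound 1 to compound 3 (0.29 log units; within the scatter); this step also lies within the scatter, whereas the step from thiophen-2-yl to 4-nitrophenyl lay beyond it. Nothing available explains these numbers.

The compounds shown cover only nitro and fluoro at this position, so it remains open whether an amine or a carboxylic acid there would stay in the same range. As far as these compounds go, it is also open whether a plain phenyl, with only hydrogen at that spot, would do so.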